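Halogen swap on the aryl ring of compound 1

A few compounds are considered here, and "the series" means these few. Any claim that something is new, unique, unknown or untested is made for them only; others in the source may bear on it.

Compound 1 `Cc1cc(Nc2ccc(C(=O)/C=C/c3ccccc3Cl)cc2)n2nc(SCc3nc4ccccc4[nH]3)nc2n1` gives the highest of the two numbers in a functional assay on SW-620 cells (Homo sapiens) for cytotoxicity, read by MTT assay, with stated times of 4 h and 72 h, tested at 2 uM (a lower number here means a stronger inhibitor, a higher number a weaker inhibitor), at 680 nM. Its nearest neighbour is compound 2 `Cc1cc(Nc2ccc(C(=O)/C=C/c3ccc4ccccc4c3)cc2)n2nc(SCc3cccc4ccccc34)nc2n1`, which in this assay gives 68 nM; of this pair only the two values are known. Compound 3 `Cc1cc(Nc2ccc(C(=O)/C=C/c3ccccc3F)cc2)n2nc(SCc3nc4ccccc4[nH]3)nc2n1` differs from compound 1 by fluoro in place of chloro on an aromatic carbon. Among the compounds with values here, no measured pair carries this change, so the step is expected to stay within the scatter of this assay, with no clear direction. For compound 3 the estimate is 800 nM, within 350 nM to 1800 nM. The expected step is therefore a 1.2-fold higher number from compound 1 to compound 3 (0.07 log units; within the scatter).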

Compound 3, half-maximal inhibitory concentration: 250 nM
For compound 3 the middle estimate is 3.2-fold (0.51 log units) above the measured one; the whole stated range lies above it.
By their numbers in this assay, from the lowest: compound 2; then compound 3; then compound 1.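

Fluoro in place of chloro on this aromatic carbon, ortho to a large group, gives a 2.7-fold lower number from compound 1 to compound 3 (0.43 log units; beyond the scatter) in this assay, the only single-place pair in the series so far. The halogen at this position therefore affects the read-out, although the step is modest. No measurement at hand accounts for the step.

Still open, on these data alone, is whether hydrogen, methoxy or an amine on the same carbon would move the number further. Also open, as far as these compounds go, is whether the swap gives a similar step when the rest of compound 1 changes.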